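The compounds below may be only part of what the source reports. "The series", "measured", "known", "first", "only" and "open" are said of these compounds alone.

In an in vitro ADME assay on microsomes from liver (Mus musculus) for pharmacokinetics, read by LC-MS, with a stated time of 10 min, tested at 1 uM (a lower number here means slower removal, a higher number faster removal of the compound), compound 1 `Cc1ccc(NC(=O)[C@H]2CN(C)C[C@@H]2c2ccc(/C=C/C(=O)Nc3ccccc3N)cc2)cc1` gives 62 mL/min/kg, compound 2 `CN1C[C@H](C(=O)Nc2ccc(Br)cc2)[C@@H](c2ccc(/C=C/C(=O)Nc3ccccc3N)cc2)C1` gives 16 mL/min/kg and compound 3 `CN1C[C@H](C(=O)Nc2cccc(F)c2)[C@@H](c2ccc(/C=C/C(=O)Nc3ccccc3N)cc2)C1` gives 56 mL/min/kg. Compound 3 thus lies within the scatter of compound 1 and well clear of compound 2. Compound 4 `CN1C[C@H](C(=O)Nc2ccc(F)c(F)c2)[C@@H](c2ccc(/C=C/C(=O)Nc3ccccc3N)cc2)C1` differs from compound 3 by fluoro in place of hydrogen on an aromatic carbon, turning 3-fluorophenyl into 3,4-difluorophenyl. For the measured compounds named here, no measured step adds fluoro to such a ring. The nearest evidence is a 3.9-fold lower number from compound 1 to compound 2 (0.59 log units; beyond the scatter), with bromo in place of methyl, and a 3.5-fold higher number from compound 2 to compound 3 (0.54 log units; beyond the scatter), so changes on this ring can matter. Yet a 1.1-fold lower number from compound 1 to compound 3 (0.04 log units; within the scatter) stays within the scatter. A small downward step is therefore expected, a 1.3-fold lower number from compound 3 to compound 4 (0.12 log units; within the scatter). For compound 4 the estimated value is 42 mL/min/kg, with an expected range of 20 mL/min/kg to 80 mL/min/kg.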

Compound 4, clearance: 46 mL/min/kg
Compound 4: middle estimate off by 1.1-fold (0.04 log units), on the low side; the measured number falls inside the stated range.
By their numbers in this assay, from the lowest: compound 2; then compounds 4, 3 and 1 (each within the scatter of the next).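

In this assay a fluoro in place of hydrogen, para to a large group, gives a 1.2-fold lower number from compound 3 to compound 4 (0.09 log units; within the scatter) and so makes no clear difference at this position, and a 1.3-fold lower number from compound 1 to compound 4 (0.13 log units; within the scatter) also lies within the scatter. Compound 2 remains apart, with a 2.9-fold higher number from compound 2 to compound 4 (0.46 log units; beyond the scatter) pointing to 4-bromophenyl as the one ring here that stands clear of the others. Nothing measured here explains this result. Still open, on these data alone, is whether an amine or a carboxylic acid at this position would shift the clearance, and whether a chloro group there would match bromo.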